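The source may hold more compounds than are shown below. What is called first, only, known or untested is meant among the compounds shown, and "the series" means these compounds.

Compound 2 `O=c1nc(N2CCN(NCC3CCCC3)CC2)sc2c([N+](=O)[O-])cc(C(F)(F)F)cc12` was tested in an ADME assay on Vero cells (Chlorocebus sabaeus) for cytotoxicity, read by MTT assay, with a stated time of 72 h; a lower number here means that less compound is tolerated, a higher number that more compound is tolerated. In this assay compound 2 gives > 64 ug/mL, a value that is a limit of the assay and not a number. Compound 1 `O=c1nc(N2CCN(NC3CCCCC3)CC2)sc2c([N+](=O)[O-])cc(C(F)(F)F)cc12` is its closest measured neighbour, differing from it only in a cyclohexyl group where compound 2 carries a cyclopentylmethyl group on the amine nitrogen. In this assay compound 1 gives > 64 ug/mL, which is also a limit. Going by the values given here, the step that the two limits leave unreadable from compound 1 to compound 2 is left unreadable by these two limits, and the only evidence that touches the series is the limit of > 64 ug/mL in this assay, at which 2 of the 2 values shown sit. Compound 3 `CN(CC1CCCCC1)N1CCN(c2nc(=O)c3cc(C(F)(F)F)cc([N+](=O)[O-])c3s2)CC1` is the next compound, differing from compound 2 by (cyclohexylmethyl)(methyl)amino in place of (cyclopentylmethyl)amino on an amine nitrogen in a ring. Among the compounds with values here, only the step from compound 1 to compound 2 bears on this change, and it gives no size and no direction, so no step beyond the scatter can be predicted in this assay. Compound 3 is therefore expected at 64 ug/mL, between 32 ug/mL and 128 ug/mL, most likely reported again as a limit. The step of a number no higher from compound 2 to compound 3 (the limit leaves the size open) is expected to lie within the usual scatter.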

Compound 3, half-maximal cytotoxic concentration: > 64 ug/mL
Compound 3: a limit, no number; the forecaster's own chance of this, stated with the estimate: 75%; the middle value sits exactly at the limit.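

In this assay compound 3 gives > 64 ug/mL, which is a limit of the assay and not a number. Going by these compounds alone, compound 1 and compound 2 also stand at limits, and no step among the three compounds can be read. The compounds shown leave open how much of each is actually tolerated, and whether exchanging these groups on the amine nitrogen changes that at all: the limit of > 64 ug/mL in this assay, at which 3 of the 3 values shown sit.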